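Swapping the chain's ethyl end for an acetyl group

This account rests on a few compounds, and the source may have more. Where it says the series, first, only, none or still open, it means among the compounds named here.

Compound 3 `C=CCc1cc(C(C)=O)c(O)cc1OCCCCCCC` gives 8% in an assay on isolated protein for binding affinity to leukotriene B4 receptor 1 (Homo sapiens), tested at 1 uM (a lower number here means less inhibition, a higher number more inhibition at the concentration tested (going by the name of the read-out)), the lowest of the three numbers measured, though compound 2 `C=CCc1cc(C(C)=O)c(O)cc1OCCCCCC`, with 9%, sits within the scatter of it. Compound 1 `C=CCc1cc(C(C)=O)c(O)cc1OCCCCCCCC#N`, with 52%, stands well above both. Compound 4 `C=CCc1cc(C(C)=O)c(O)cc1OCCCCCC(C)=O` differs from compound 3 by acetyl in place of ethyl on a saturated chain carbon, five bonds along the chain from an oxygen on an aromatic ring.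

Among the compounds with values here, the steps that bear on this change are a number 44 percentage points lower from compound 1 to compound 3 (beyond the scatter) and a number 43 percentage points lower from compound 1 to compound 2 (beyond the scatter): removing the nitrile, itself a hydrogen-bond acceptor, cost much inhibition. The acetyl group brings an acceptor back near the chain end, so a rise is expected, though a ketone is not a nitrile. For compound 4 the expected step is a number 22 percentage points higher from compound 3 to compound 4 (beyond the scatter), giving an estimated 30% in this assay, within 8% to 55%.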

Compound 4, a percentage reported as inhibition, at one concentration (the size of the read-out at that concentration, not a potency): 58%
Compound 4: the middle estimate sits 28 percentage points below what was measured, outside the stated range (above it).
By their numbers in this assay, from the lowest: compounds 3 and 2 (each within the scatter of the next); then compounds 1 and 4 (each within the scatter of the next).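

On a saturated chain carbon, five bonds along the chain from an oxygen on an aromatic ring, acetyl in place of ethyl gives a number 50 percentage points higher from compound 3 to compound 4 (beyond the scatter) and acetyl in place of methyl gives a number 49 percentage points higher from compound 2 to compound 4 (beyond the scatter) in this series. The nitrile is therefore not the only chain ending found with high inhibition: acetyl in place of 2-cyanoethyl gives a number 6 percentage points higher from compound 1 to compound 4 (within the scatter) and sets no order between the two. No measurement here explains the rise.

The compounds shown leave open whether a carboxylic acid, an amide or a longer chain carrying the acetyl would keep this level of inhibition.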